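Benzyloxy in place of pentyloxy on the pyridine-bearing urea

The compounds below may be only part of what the source reports. "The series", "measured", "known", "first", "only" and "open" are said of these compounds alone.

Measured so far in an assay on HEK cells for antagonist activity at transient receptor potential cation channel subfamily V member 1 (Homo sapiens), read by FLIPR; a lower number here means a stronger inhibitor, a higher number a weaker inhibitor:
Compound 1 `O=C(NCc1ccc(C(F)(F)F)nc1N1CCC(Cc2ccccc2)CC1)Nc1cccc2[nH]c(=O)ccc12` gives 1.59 nM.
Compound 2 `CCCN(CCC)c1nc(C(F)(F)F)ccc1CNC(=O)Nc1cccc2[nH]c(=O)ccc12` gives 5.21 nM.
Compound 3 `CCCCCOc1nc(C(F)(F)F)ccc1CNC(=O)Nc1cccc2[nH]c(=O)ccc12` gives 2.72 nM.

All three compounds share the same urea-linked core and differ only in the substituent on the aromatic carbon of the trifluoromethyl-bearing ring. The values of compound 3, compound 1 and compound 2 all lie within the usual scatter of one another, so compound 3 cannot be placed apart from either of the other two on these numbers.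

Compound 4 `O=C(NCc1ccc(C(F)(F)F)nc1OCc1ccccc1)Nc1cccc2[nH]c(=O)ccc12` is the next member: phenyl in place of butyl on a saturated chain carbon bound to an oxygen on an aromatic ring. For the measured compounds named here, no measured step covers exactly this exchange. The only single-point step shown, a 1.9-fold lower number from compound 2 to compound 3 (0.28 log units; within the scatter), replaced one whole substituent at this position by another without moving the number beyond the scatter, and compound 1, which carries a phenyl-bearing group at the same aromatic carbon, gives a value within the scatter of compound 3. On that basis compound 4 is expected to stay close to compound 3 in this assay, with a step of a 1.1-fold higher number from compound 3 to compound 4 (0.04 log units; within the scatter) that is not expected to exceed the scatter. Compound 4 is therefore estimated at 3 nM, within a range of 1 nM to 9 nM.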

Compound 4, half-maximal inhibitory concentration: 1.2 nM
For compound 4 the middle estimate is 2.5-fold (0.40 log units) above the measured one, within the range that was stated.
By their numbers in this assay, from the lowest: compounds 4, 1, 3 and 2 (each within the scatter of the next, the first and the last beyond it).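

In this assay, for the compounds shown here, the exchange of butyl for phenyl on a saturated chain carbon bound to an oxygen on an aromatic ring gives a 2.3-fold lower number from compound 3 to compound 4 (0.36 log units; beyond the scatter) and is the first step at this position to pass the scatter, if only modestly. The earlier step, a 1.9-fold lower number from compound 2 to compound 3 (0.28 log units; within the scatter), stayed within the scatter, while the change from dipropylamino to benzyloxy gives a 4.3-fold lower number from compound 2 to compound 4 (0.64 log units; beyond the scatter) and so shows that the substituent on this aromatic carbon can shift the number readably. Nothing measured here accounts for either step.

The compounds shown leave open how a phenethyloxy chain or a benzylamino group on this aromatic carbon would read in this assay. They also leave open what a fluorine or a methoxy group on the phenyl would do to the number.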